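The source may hold more compounds than are shown below. What is called first, only, known or untested is meant among the compounds shown, and "the series" means these compounds.

The series shares one core, seen in compound 1 `Cc1cccc(C)c1NN=C1CCC(C)n2c1ncc(C(=O)O)c2=O`, and varies only the group on an amine nitrogen. In a functional assay on the whole organism with Rattus norvegicus as the target (a lower number here means that less compound is needed, a higher number that more compound is needed for the effect), compound 1 gives 320 umol/kg. Compound 2 `CC1CCC(=NNc2ccc(Cl)cc2Cl)c2ncc(C(=O)O)c(=O)n21` carries a 2,4-dichlorophenyl in place of the 2,6-dimethylphenyl. In this assay compound 2 reaches only the limit of the assay, > 100 umol/kg, and no number. Compound 3 `CC1CCC(=NNc2c(Cl)cccc2Cl)c2ncc(C(=O)O)c(=O)n21` bears a 2,6-dichlorophenyl instead. In this assay compound 3 likewise stops at a limit, > 100 umol/kg, which is not a number. Compound 3 therefore stands at the limit of > 100 umol/kg in this assay, at which 2 of the 3 values shown sit, so where it sits relative to compound 1 cannot be read. The three measured steps, a step that the limit leaves unreadable from compound 1 to compound 2, a step that the limit leaves unreadable from compound 1 to compound 3 and a step that the two limits leave unreadable from compound 2 to compound 3, are all left unreadable by these limits, so none of them gives a size or a direction to lean on.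

Compound 4 `Cc1cc(NN=C2CCC(C)n3c2ncc(C(=O)O)c3=O)ccc1Br` is the next analogue: 4-bromo-3-methylphenyl in place of 2,6-dichlorophenyl on an amine nitrogen. For the measured compounds named here, no measured step bears readably on this change, so the expectation rests on the whole set sitting weak or at a limit. The step that the limit leaves unreadable from compound 3 to compound 4 that the estimate implies is expected to be small and uncertain. Compound 4 is expected to give about 300 umol/kg in this assay, between 100 umol/kg and 1000 umol/kg, with a fair chance that only a limit is reported.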

Compound 4, dose for 50% inhibition: > 100 umol/kg
Compound 4: a limit, no number; the forecaster's own chance of this, stated with the estimate: 50%; the middle value lies beyond the limit too.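

In this assay compound 4 stops at a limit (> 100 umol/kg) and gives no number. Its steps from compound 1, compound 2 and compound 3 therefore cannot be read. The compounds shown leave open how far compound 2, compound 3 and compound 4 actually lie from compound 1, and in which direction.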